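Swapping chloro for hydroxy on an inactive dichlorophenyl compound

The compounds below may be only part of what the source reports. "The series", "measured", "known", "first", "only" and "open" are said of these compounds alone.

Measured in a functional assay on A549 cells (Homo sapiens) for cytotoxicity, read by MTT assay, with a stated time of 72 h; on this read-out lower numbers stand for stronger inhibition and higher numbers for weaker inhibition:
Compound 1 `COc1cccc(/C=C2\CCC/C(=C\c3ccc(O)cc3)C2=O)c1OC`: > 20000 nM (a limit)
Compound 2 `COc1cccc(/C=C2\CCC/C(=C\c3ccc(Cl)c(Cl)c3)C2=O)c1OC`: > 20000 nM (a limit)

Compound 2 gives no number, only the limit > 20000 nM. For the measured compounds named here, the one other measured value, that of compound 1, is also a limit.

Compound 3 `COc1cccc(/C=C2\CCC/C(=C\c3ccc(O)c(Cl)c3)C2=O)c1OC` differs from compound 2 in one place: hydroxy in place of chloro on an aromatic carbon. In words, hydroxy replaces chloro on an aromatic carbon, ortho to a chloro group and para to a large group, so 3,4-dichlorophenyl becomes 3-chloro-4-hydroxyphenyl.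

Going by the values given here, the only measured step that bears on this is a step that the two limits leave unreadable from compound 1 to compound 2. It has no readable size, and the evidence here is the limit of > 20000 nM in this assay, at which 2 of the 2 values shown sit. Compound 3 carries a hydroxy, as compound 1 does, and a chloro, as compound 2 does. Neither of those compounds gave a number in this assay, so no step beyond the scatter, in either direction, is expected, and another limit is the likeliest report.

The estimate means an expected a number no higher from compound 2 to compound 3 (the limit leaves the size open). For compound 3 the estimated value is 20000 nM, with an expected range of 7000 nM to 30000 nM.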

Compound 3, half-maximal inhibitory concentration: > 20000 nM
Compound 3 gave a limit, no number; the forecaster's own chance of this, stated with the estimate: 65%; the middle value sits exactly at the limit.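

In this assay, for the compounds shown here, compound 1, compound 2 and compound 3 all give only a limit and no number, so no step among them can be read. The compounds shown leave open what number any of the three would give, and so whether swapping hydroxy and chloro on the aromatic ring changes the result at all.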